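The source may hold more compounds than are shown below. What is called first, only, known or untested is meant among the compounds shown, and "the series" means these compounds.

Working notes on the series.

For the measured compounds named here, the shared core carries on its ring amine nitrogen a variable group, and the three measured members give no readable number. Compound 2 `COc1cc(N)c(Cl)cc1NC(=O)C1CCN(C/C=C/c2ccccc2)CC1` in a functional assay on the whole organism for antagonist activity, with Mus musculus as the target (a lower number here means that less compound is needed, a higher number that more compound is needed for the effect), gives > 10 mg/kg, which is a limit of the assay and not a number. Compound 1 `CCCCCCCN1CCC(C(=O)Nc2cc(Cl)c(N)cc2OC)CC1` in this assay gives > 10 mg/kg, again a limit. Compound 3 `COc1cc(N)c(Cl)cc1NC(=O)C1CCN(CC2CCC2)CC1` in this assay gives > 10 mg/kg, also a limit. All three values sit at one point, (the limit of > 10 mg/kg in this assay, at which 3 of the 3 values shown sit), so every measured step is blind: a step that the two limits leave unreadable from compound 1 to compound 2, a step that the two limits leave unreadable from compound 1 to compound 3 and a step that the two limits leave unreadable from compound 2 to compound 3. Neither hexyl, 2-phenylethenyl nor cyclobutyl at this place has shown a measurable dose.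

Compound 4 `CCCCN1CCC(C(=O)Nc2cc(Cl)c(N)cc2OC)CC1` differs from compound 2 as follows: propyl in place of 2-phenylethenyl on a saturated chain carbon bound to an amine nitrogen in a ring. The three measured steps bear on it only in that they all fail to leave the limit, so no direction and no size can be read from them. What they do show is that three different groups at this position all stay at the limit, which makes a limit for compound 4 the likeliest outcome too.

Compound 4 in this assay is therefore expected to give 15 mg/kg, with a range from 5 mg/kg to 50 mg/kg. The expected step is a step that the limit leaves unreadable from compound 2 to compound 4, that is, no change that could be read against the limit.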

Compound 4, dose for half-maximal effect: > 10 mg/kg
Compound 4: only a limit was reported (the forecaster's own chance of this, stated with the estimate: 75%); the middle value is on the limit's open side.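

No new step can be read: the steps joining compound 4 to compound 1, compound 2 and compound 3 all run between limits and have no readable size. All four compounds sit at one point: the limit of > 10 mg/kg in this assay, at which 4 of the 4 values shown sit.

The compounds shown leave open which group at this place on the shared core, if any, gives a measurable dose in this assay.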